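The compounds below may be only part of what the source reports. "The series", "measured", "known", "first", "only" and "open" are said of these compounds alone.

Working notes on the series. Compound 1 `Cc1cc(C#N)cc(C)c1Oc1nc(Nc2ccc(C#N)cc2)ncc1-c1cccnc1` gives 13500 nM in an ADME assay on MT4 cells (Homo sapiens) for cytotoxicity, read by MTT assay, with a stated time of 5 days; on this read-out lower numbers stand for higher toxicity in this test and higher numbers for lower toxicity in this test. Compound 2 `Cc1cc(C#N)cc(C)c1Oc1nc(Nc2ccc(C#N)cc2)ncc1-c1cncnc1` gives only a limit, > 298000 nM, in this assay. Compound 2 thus stands at the limit of > 298000 nM in this assay, at which 1 of the 2 values shown sits, the upper edge of the numbers shown. Among the measured compounds shown here, the single measured step at this position is an at least 22-fold higher number from compound 1 to compound 2 (1.34 log units; beyond the scatter), and it is the only guide here. Compound 3 `Cc1cc(C#N)cc(C)c1Oc1nc(Nc2ccc(C#N)cc2)ncc1-c1ccc(F)cc1` carries 4-fluorophenyl in place of pyrimidin-5-yl on an aromatic carbon. Compound 3 is expected to bring the number back down, an at least 14-fold lower number from compound 2 to compound 3 (1.17 log units; beyond the scatter). The basis is compound 1, which with pyridin-3-yl on that aromatic carbon gives 13500 nM. Compound 3 is estimated at 20000 nM, within 5000 nM to 150000 nM.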

Compound 3, half-maximal cytotoxic concentration: 42700 nM
Compound 3: middle estimate off by 2.1-fold (0.33 log units), on the low side; the measured number falls inside the stated range.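

At this position, 4-fluorophenyl in place of pyrimidin-5-yl gives an at least 6.9-fold lower number from compound 2 to compound 3 (0.84 log units; beyond the scatter) in this assay, so a ring of carbon only does not keep the number of compound 2. 4-fluorophenyl in place of pyridin-3-yl gives a 3.2-fold higher number from compound 1 to compound 3 (0.50 log units; beyond the scatter), so ring nitrogen is not needed for a number above that of compound 1, and its presence alone does not order the three compounds. The value of compound 2 is a limit, so the first step has no fixed size: the limit of > 298000 nM in this assay, at which 1 of the 3 values shown sits. Still open, on these data alone, is how a ring carrying an amine or a carboxylic acid would read at this position in this assay.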